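Swapping Trifluoromethyl for Cyano at the Limit of Detection

The compounds below may be only part of what the source reports. "The series", "measured", "known", "first", "only" and "open" are said of these compounds alone.

In a physicochemical assay for solubility (on this read-out lower numbers stand for lower solubility and higher numbers for higher solubility), compound 3 (`O=C(Nc1ccc(C(F)(F)F)cc1Cl)c1ccc2ccccc2c1O`) gives < 1 ug/mL as its result, and this is a limit of the assay and not a number. Compound 2 (`Cc1ccc(NC(=O)c2cc(Cl)ccc2O)cc1`) gives < 1 ug/mL in this assay and this too is a limit. Compound 1 (`O=C(Nc1ccc([N+](=O)[O-])cc1Cl)c1c(O)cccc1O`) is the only one of these with a true number, at 7.9 ug/mL in this assay as a measured reading. Compound 3 therefore stands at the limit of < 1 ug/mL in this assay, at which 2 of the 3 values shown sit, and has no number of its own.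

The next compound to be read is compound 4 (`N#Cc1ccc(NC(=O)c2ccc3ccccc3c2O)c(Cl)c1`). It carries cyano in place of trifluoromethyl on an aromatic carbon, a carbon that is meta to a chloro group and para to a large group. The counted change is cyano in place of trifluoromethyl on an aromatic carbon and the rest of the structure stays the same.

Among the measured compounds shown here, no two measured compounds differ in one place only, so no measured step can size this change. In this assay the expected step is small and upward, with a number no lower from compound 3 to compound 4 (the limit leaves the size open) as the estimate, and it may not clear the usual scatter. This expectation starts from compound 3 at < 1 ug/mL as a limit. For compound 4 the estimate is 1 ug/mL with an expected range from 0.5 ug/mL to 3 ug/mL in this measure.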

Compound 4, solubility: 6 ug/mL
Estimate against measurement, compound 4: 6.0-fold (0.78 log units) below; measured number outside the range, above it.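

In this assay, this aromatic carbon, para to a large group, is a place where a single swap moves the reading: cyano in place of trifluoromethyl gives an at least 6.0-fold higher number from compound 3 to compound 4 (0.77 log units; beyond the scatter). Among the compounds shown here, this is the first step in the set that isolates one group, as the earlier compounds differ from one another in more than one place and could not show what a change at this carbon does on its own. The step can only be stated as a minimum because the value of compound 3 is a limit and not a number: the limit of < 1 ug/mL in this assay, at which 2 of the 4 values shown sit.

The compounds shown leave open whether this rise is particular to cyano or would also appear with another group on the same carbon, such as an amine or a carboxylic acid. For the compounds shown here, they also leave open whether the same swap of trifluoromethyl for cyano would move the reading by a similar amount on a different core, since this single pair is the only evidence for the change.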